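Series notes: aryl change on the sulfonamide nitrogen

The compounds below may be only part of what the source reports. "The series", "measured", "known", "first", "only" and "open" are said of these compounds alone.

Measured so far in a functional assay on cells (leukaemia cell line, Homo sapiens) for inhibition, read by sulforhodamine B assay, with a stated time of 48 h; a lower number here means that less compound is tolerated, a higher number that more compound is tolerated:
compound 1 `O=S(=O)(Nc1ccc(Cl)cc1Cl)c1ccc(-c2cnc(C3CC3)o2)cc1` gives > 100000 nM, which is a limit of the assay and not a number.
compound 2 `O=S(=O)(Nc1cccc(Cl)c1)c1ccc(-c2cnc(C3CC3)o2)cc1` gives > 100000 nM, which is likewise a limit and not a number.

Compound 2 thus stands at the limit, and the step that the two limits leave unreadable from compound 1 to compound 2 cannot be read. For the measured compounds named here, the one piece of evidence on the measured step is the limit of > 100000 nM in this assay, at which 2 of the 2 values shown sit. Compound 3 `COc1cc(NS(=O)(=O)c2ccc(-c3cnc(C4CC4)o3)cc2)ccc1F` differs from compound 2 in one place: 4-fluoro-3-methoxyphenyl in place of 3-chlorophenyl on a sulfonamide nitrogen. Going by the values given here, the only measured step that touches the group on the sulfonamide nitrogen is the one from compound 1 to compound 2, and its size is not readable; it gives no guide to the size of a change on the sulfonamide nitrogen, in either direction. With both measured values sitting at the limit, the expectation for compound 3 in this assay is that the step of a number no higher from compound 2 to compound 3 (the limit leaves the size open) is none beyond the scatter. Compound 3 is accordingly estimated at 100000 nM, with a range from 30000 nM to 300000 nM, and most likely reported only as a limit.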

Compound 3, concentration lethal to 50% of the cells: > 100000 nM
Compound 3 gave a limit, no number; the forecaster's own chance of this, stated with the estimate: 75%; the middle value sits exactly at the limit.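

In this assay compound 3 gives > 100000 nM, which is a limit of the assay and not a number. The steps to compound 3 from compound 1 and from compound 2 therefore cannot be read. Whether any of these groups on the sulfonamide nitrogen changes the read-out remains open, with all the evidence resting on one limit: the limit of > 100000 nM in this assay, at which 3 of the 3 values shown sit.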